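Hydroxy on the aryl ketone of compound 3

The source may hold more compounds than are shown below. What is called first, only, known or untested is meant among the compounds shown, and "the series" means these compounds.

In a functional assay on HCT-116 cells (Homo sapiens) for inhibition, read by MTT assay, with a stated time of 48 h (on this read-out higher numbers stand for weaker inhibition and lower numbers for stronger inhibition), compound 1 (`COc1ccc(-n2c(SC)nnc2-c2cc(OC)c(OC)c(OC)c2)cc1`) gives > 60000 nM as a limit of the assay, not a number. Going by the values given here, compound 2 (`COc1ccc(-n2c(SCc3ccc(F)cc3)nnc2-c2cc(OC)c(OC)c(OC)c2)cc1`) gives 38700 nM as the only measured number. Compound 3 (`COc1ccc(C(=O)CSc2nnc(-c3cc(OC)c(OC)c(OC)c3)n2-c2ccc(OC)cc2)cc1`) gives > 60000 nM as a limit too, and this sits at the limit of > 60000 nM in this assay, at which 2 of the 3 values shown sit, in the notes so far.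

Compound 4 (`COc1ccc(-n2c(SCC(=O)c3ccc(OC)c(O)c3)nnc2-c2cc(OC)c(OC)c(OC)c2)cc1`) differs from compound 3 by hydroxy in place of hydrogen on an aromatic carbon with 4-methoxyphenyl becoming 3-hydroxy-4-methoxyphenyl, the hydroxy standing ortho to a methoxy group. The measured steps change only the group on the saturated chain carbon bound to sulfur, so they bear on this change only indirectly. They comprise an at least 1.5-fold lower number from compound 1 to compound 2 (0.19 log units; that floor lies within the scatter) and an at least 1.5-fold higher number from compound 2 to compound 3 (0.19 log units; that floor lies within the scatter) and a step that the two limits leave unreadable from compound 1 to compound 3 as the full record. None of them touches this aromatic ring, so only a small shift toward lower numbers in this assay is expected. The expected move is an at least 1.3-fold lower number from compound 3 to compound 4 (0.12 log units; that floor lies within the scatter) and it remains a rough estimate. Compound 4 is estimated at 45000 nM with an expected range of 18000 nM to 80000 nM and a real chance of a limit instead of a number.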

Compound 4, half-maximal inhibitory concentration: > 60000 nM
Compound 4 gave a limit, no number (the forecaster's own chance of this, stated with the estimate: 55%); middle value at least 1.3-fold (0.12 log units) from the limit.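

Adding hydroxy to the aryl ketone gives a 3-hydroxy-4-methoxyphenyl group, yet in this assay compound 4, like compound 3, gives a limit and not a number, so this position has shown no readable effect so far. Against the only measured number in the series, the change of group gives an at least 1.5-fold higher number from compound 2 to compound 4 (0.19 log units; that floor lies within the scatter), which leaves the 4-fluorophenyl compound as the sole one with a number. The steps from compound 3 to compound 4 and from compound 1 to compound 4 cannot be read, and the series gathers at one end of the read-out: the limit of > 60000 nM in this assay, at which 3 of the 4 values shown sit.

On these data alone, whether hydroxy on this aromatic carbon changes anything remains open, since any shift stays hidden behind the two limits. As far as these compounds go, how an amine in place of that hydroxy, or a longer chain on the sulfur, would read in this assay is also open.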